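Aryl replacement on the side-chain carbonyl of compound 2

This account rests on a few compounds, and the source may have more. Where it says the series, first, only, none or still open, it means among the compounds named here.

Measured so far:
- compound 1 `CCC(CC)(CC)C(=O)O[C@H]1C[C@@H](C)C=C2C=C[C@H](C)[C@H](CC[C@@H]3C[C@@H](O)CC(=O)O3)C21` — 1.4 nM
- compound 2 `C[C@H]1C=C2C=C[C@H](C)[C@H](CC[C@@H]3C[C@@H](O)CC(=O)O3)C2[C@@H](OC(=O)c2ccc(F)cc2)C1` — 37 nM

In an assay for inhibition of 3-hydroxy-3-methylglutaryl-coenzyme A reductase (Rattus norvegicus) (on this read-out lower numbers stand for stronger inhibition and higher numbers for weaker inhibition), compound 1 gives 1.4 nM and compound 2 gives 37 nM. Going by the values given here, the one measured step is a 26-fold higher number from compound 1 to compound 2 (1.42 log units; beyond the scatter), which puts compound 2 at the weaker end of the two numbers recorded, with compound 1 as its only neighbour.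

Compound 3 `C[C@H]1C=C2C=C[C@H](C)[C@H](CC[C@@H]3C[C@@H](O)CC(=O)O3)C2[C@@H](OC(=O)Oc2ccccc2)C1` is not yet measured. It differs from compound 2 by phenoxy in place of 4-fluorophenyl on a carbonyl carbon. Among the compounds with values here, no measured step covers a change of this kind: the single known step swaps an aromatic group for a branched alkyl group on the same carbonyl carbon, whereas here one aromatic group gives way to another aromatic group bearing an oxygen link. That step is therefore only indirect support, showing the carbonyl substituent matters, without telling the direction for an aryl-to-aryloxy exchange. With the aromatic ring kept and the fluorine lost, a step no larger than the scatter is expected in this assay, in either direction.

For compound 3 the estimate is 40 nM (range 12 nM to 130 nM), which is expected to mean a step of a 1.1-fold higher number from compound 2 to compound 3 (0.03 log units; within the scatter).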

Compound 3, half-maximal inhibitory concentration: 83 nM
Beside the measured number, compound 3's estimate is 2.1-fold (0.32 log units) below it; measured number inside the range.
By their numbers in this assay, from the lowest: compound 1; then compound 2; then compound 3.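

In this assay, the exchange of 4-fluorophenyl for phenoxy on this carbonyl carbon keeps one six-membered aromatic ring, yet it gives a 2.2-fold higher number from compound 2 to compound 3 (0.35 log units; beyond the scatter). This modest step shows that the position responds to a change between two ring-bearing groups, and not only to the larger exchange of a branched alkyl group for an aromatic one. The step of a 59-fold higher number from compound 1 to compound 3 (1.77 log units; beyond the scatter) exceeds a 26-fold higher number from compound 1 to compound 2 (1.42 log units; beyond the scatter) and leaves 1,1-diethylpropyl with the lowest number of the three, so both ring-bearing groups stand far from it, while the step between those two remains small by comparison, and nothing available bears on what lies behind these steps.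

Phenoxy differs from 4-fluorophenyl by both an oxygen link and the loss of fluorine, so the two changes cannot be told apart here; plain phenyl or 4-fluorophenoxy on this carbonyl carbon would separate them. Also open, as far as these compounds go, is whether a shorter branched alkyl group such as tert-butyl, or an anilino group with a nitrogen link, would sit nearer to compound 1 or to compound 3.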